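The compounds below may be only part of what the source reports. "The series", "measured", "known", "first", "only" and "open" are said of these compounds alone.

Measured compounds:
Compound 2, `CO[C@@H]1O[C@H](COc2ccc(-c3ccccc3)cc2)[C@@H](O)[C@H](O)[C@H]1Oc1ccc(OC2CCCCC2)cc1`, in a functional assay on MDA-MB-231 cells (Homo sapiens) for cytotoxicity, read by MTT assay, with a stated time of 48 h; on this read-out lower numbers stand for an effect already at smaller amounts and higher numbers for an effect only at larger amounts of compound: 36000 nM
Compound 3, `CO[C@H]1O[C@H](COc2ccc(OC3CCCCC3)cc2)[C@@H](O)[C@H](O)[C@H]1Oc1ccc(OC2CCCCC2)cc1`, in this assay: 20000 nM
Compound 1, `CO[C@@H]1O[C@H](COc2ccc3c(c2)CCCC3)[C@@H](O)[C@H](O)[C@H]1Oc1ccc(OC2CCCCC2)cc1`, in this assay: "not determined" (no result reported)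

Compound 2 gives the highest of the two numbers available in this assay, but its nearest neighbour, compound 3, lies within the usual scatter of it, so the two compounds cannot be told apart on these values. Compound 1 contributes no number.

The step under consideration leads from compound 2 to compound 4, `CO[C@@H]1O[C@H](COc2cccc(C(C)C)c2)[C@@H](O)[C@H](O)[C@H]1Oc1ccc(OC2CCCCC2)cc1`. The structural change is 3-isopropylphenyl in place of 4-phenylphenyl on an oxygen on a saturated carbon. Among the measured compounds shown here, no step between measured compounds is available to calibrate this change, and the two measured values themselves do not separate beyond the scatter. On this basis the step from compound 2 to compound 4 is expected to be small, estimated at a 1.2-fold lower number from compound 2 to compound 4 (0.08 log units; within the scatter), with no direction beyond the scatter. Compound 4 is therefore expected to give about 30000 nM in this assay, with a likely range from 10000 nM to 90000 nM.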

Compound 4, half-maximal effective concentration: 40000 nM
For compound 4 the middle estimate is 1.3-fold (0.12 log units) below the measured one; low and high end bracket the measured number.
By their numbers in this assay, from the lowest: compounds 3, 2 and 4 (each within the scatter of the next).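

In this assay, among the compounds shown here, a 1.1-fold higher number from compound 2 to compound 4 (0.05 log units; within the scatter) gives the first step at this position, and it stays within the scatter. Thus 3-isopropylphenyl in place of 4-phenylphenyl, on an oxygen on a saturated carbon, leaves the two compounds indistinguishable, even though the group shrinks from 12 heavy atoms to 9 and from two six-membered aromatic rings of carbon only to one. No measured property of these groups is available to account for this result.

On these data alone, all-carbon groups are the only kind compared at this position, so it remains open whether an amine or a carboxylic acid placed there would shift the number beyond the scatter. As far as these compounds go, it is also open whether this change would remain as small with other groups elsewhere on the shared core.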